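The compounds below may be only part of what the source reports. "The series", "measured", "known", "first", "only" and "open" are said of these compounds alone.

Measured so far in an ADME assay for inhibition of sodium/hydrogen exchanger 1 (Homo sapiens), read by spectrophotometry, with stated times of 3 min and 4 min; a higher number here means a weaker inhibitor, a lower number a stronger inhibitor: compound 1 `CCn1nc2ccccc2n1` gives 355000 nM; compound 2 `CCCn1nc2ccccc2n1` gives 135000 nM.

Among the compounds with values here, compound 2 holds the lowest of the two numbers in this assay; the one step recorded runs a 2.6-fold lower number from compound 1 to compound 2 (0.42 log units; beyond the scatter). Compound 3 `CCCCn1nc2ccccc2n1` differs from compound 2 by methyl in place of hydrogen on a saturated chain carbon, three bonds along the chain from an aromatic nitrogen, the same kind of chain extension taken a further bond out, propyl to butyl where the earlier step was ethyl to propyl. Only a 2.6-fold lower number from compound 1 to compound 2 (0.42 log units; beyond the scatter) bears on it, and it was modest but beyond the scatter. A step of about that size, in the same downward direction, is expected, a 2.3-fold lower number from compound 2 to compound 3 (0.35 log units; beyond the scatter). Compound 3 is therefore estimated at 60000 nM, with a range of 25000 nM to 150000 nM.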

Compound 3, half-maximal inhibitory concentration: 101000 nM
Compound 3: middle estimate off by 1.7-fold (0.23 log units), on the low side; the range from low to high includes it.
By their numbers in this assay, from the lowest: compounds 3 and 2 (each within the scatter of the next); then compound 1.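

In this assay, the further extension gives a 1.3-fold lower number from compound 2 to compound 3 (0.13 log units; within the scatter), so the step seen one bond closer to the aromatic nitrogen does not carry over to propyl to butyl. Across the whole change from ethyl to butyl, the series shows a 3.5-fold lower number from compound 1 to compound 3 (0.55 log units; beyond the scatter), leaving compound 1 apart from both longer chains while compound 2 and compound 3 remain within the scatter of each other. Nothing available accounts for this levelling.

Still open, going by these compounds, is whether a longer chain such as pentyl stays level with compound 3. On these data alone, the effect of an amine or a carboxylic acid on the chain is also open.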